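This account rests on a few compounds, and the source may have more. Where it says the series, first, only, none or still open, it means among the compounds named here.

Among the three compounds measured so far in a functional assay on DU-145 cells (Homo sapiens) for inhibition, read by trypan blue exclusion, with a stated time of 72 h (on this read-out lower numbers stand for stronger inhibition and higher numbers for weaker inhibition), compound 1 `Cn1c(=O)c(S(=O)(=O)c2ccc(F)cc2)cc2cnc(Nc3ccc4occc4c3)nc21` gives 5000 nM. Compound 3 `Cn1c(=O)c(S(=O)(=O)c2ccc(Br)cc2)cc2cnc(Nc3ccc4[nH]ccc4c3)nc21` gives 5000 nM, so the two are level at the digits shown and together hold the lowest number of the three. Compound 2 `Cn1c(=O)c(S(=O)(=O)c2ccc(F)cc2F)cc2cnc(Nc3ccc4occc4c3)nc21` stands apart at 15000 nM.

The next compound, compound 4 `Cn1c(=O)c(S(=O)(=O)c2ccc(F)cc2)cc2cnc(Nc3cccc4[nH]ccc34)nc21`, keeps the core of compound 1 and changes one group: 1H-indol-4-yl in place of 1-benzofuran-5-yl on a nitrogen on an aromatic ring. In words, 1H-indol-4-yl replaces 1-benzofuran-5-yl on a nitrogen on an aromatic ring.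

Within the data shown here, the only measured step that changes one place is a 3.0-fold higher number from compound 1 to compound 2 (0.48 log units; beyond the scatter), where fluoro takes the place of hydrogen on an aromatic carbon. That step lies in a different part of the structure, so it gives no direct measure of the present change and serves only as a rough guide to how far one edit can move this assay. Compound 3 differs from compound 1 in more than one place, so its equal number isolates no single change.

Among the measured compounds shown here, with no measured step on this group, no change beyond the scatter is expected, and the direction remains open. The expected step is a 1.1-fold lower number from compound 1 to compound 4 (0.05 log units; within the scatter). For compound 4 the estimated value is 4500 nM, with an expected range of 1500 nM to 15000 nM.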

Compound 4, half-maximal inhibitory concentration: 750 nM
The estimate for compound 4 lay 6.0-fold (0.78 log units) above the measured number; the whole stated range lies above it.
By their numbers in this assay, from the lowest: compound 4; then compounds 1 and 3 (each within the scatter of the next); then compound 2.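

In this assay, among these compounds, 1H-indol-4-yl in place of 1-benzofuran-5-yl on a nitrogen on an aromatic ring gives a 6.7-fold lower number from compound 1 to compound 4 (0.82 log units; beyond the scatter) and so shows that this place can move the number beyond the scatter, which the earlier compounds could not show because none of their single-place steps fell here. Among the compounds shown here, the step also runs towards stronger inhibition, while the only earlier single-place step, a 3.0-fold higher number from compound 1 to compound 2 (0.48 log units; beyond the scatter), runs towards weaker inhibition and lies at a different place in the structure. No evidence at hand accounts for the lower number of compound 4.

The change alters two things at once, the ring hetero atom, with oxygen leaving and nitrogen entering along with a hydrogen-bond donor, and the point of attachment written in the two group names, so the compounds shown do not tell which of these goes with the lower number. Also open, going by these compounds, are whether the second fluoro of compound 2 would raise the number on the 1H-indol-4-yl compound as it does on the 1-benzofuran-5-yl one, and how a plain phenyl group or a phenyl ring carrying a dimethylamino group would fare on this nitrogen.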